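Capping the Ring Nitrogen with Pyrimidine

The source may hold more compounds than are shown below. What is called first, only, known or untested is meant among the compounds shown, and "the series" means these compounds.

Compound 3 `c1cc2[nH]cc(CCCN3CCNCC3)c2cc1-n1cnnc1` carries the shared core with an unsubstituted amine nitrogen in its six-membered ring. In an assay on CHO cells for displacement of a labelled ligand from 5-hydroxytryptamine receptor 1B (Homo sapiens) (a lower number here means a stronger inhibitor, a higher number a weaker inhibitor), compound 3 gives 145 nM, the highest of the two single numbers in the set; its nearest neighbour compound 1 `c1c[nH]c(CN2CCN(CCCc3c[nH]c4ccc(-n5cnnc5)cc34)CC2)n1` gives 36 nM, and compound 2 `NC(=O)C(c1ccccc1)N1CCN(CCCc2c[nH]c3ccc(-n4cnnc4)cc23)CC1` gives 55 nM; 13 nM (2 entries) across several entries, so it has no single number. Going by the values given here, the one measured step that ends at compound 3, a 4.0-fold higher number from compound 1 to compound 3 (0.61 log units; beyond the scatter), shows that replacing the (1H-imidazol-2-yl)methyl on that ring nitrogen by hydrogen raises the number. Compound 4 `c1cnc(N2CCN(CCCc3c[nH]c4ccc(-n5cnnc5)cc34)CC2)nc1` goes back the other way: pyrimidin-2-yl in place of hydrogen on an amine nitrogen in a ring. Among the compounds with values here, no measured pair covers this exact change, but the only related step is modest and points toward a lower number when that nitrogen carries a group, so a lowering of similar size is expected for compound 4 in this assay, with the spread of compound 2 in the several entries of compound 2 in this assay, 55 nM; 13 nM (2 entries) arguing for a wide range. Compound 4 is therefore estimated at 40 nM (from 12 nM to 130 nM), which means a 3.6-fold lower number from compound 3 to compound 4 (0.56 log units; beyond the scatter) is expected.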

Compound 4, half-maximal inhibitory concentration: 0.5 nM
For compound 4 the middle estimate is 80-fold (1.90 log units) above the measured one; the whole stated range lies above it.
By their numbers in this assay, from the lowest: compound 4; then compound 1; then compound 3.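

In this assay, going by these compounds alone, the amine nitrogen in the ring proves far more sensitive to its substituent than the earlier compounds showed: the only earlier step there was modest, whereas pyrimidin-2-yl in place of hydrogen gives a 290-fold lower number from compound 3 to compound 4 (2.46 log units; beyond the scatter). The identity of the group matters, not merely the presence of one, as exchanging (1H-imidazol-2-yl)methyl for pyrimidin-2-yl still gives a 72-fold lower number from compound 1 to compound 4 (1.86 log units; beyond the scatter). Nothing measured here accounts for the size of this drop.

The compounds shown leave open whether the two ring nitrogens of pyrimidin-2-yl are needed, which a phenyl or pyridin-2-yl group on the same nitrogen would test. They also leave open whether a pyrimidin-2-ylmethyl group would keep the low number.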